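This account rests on a few compounds, and the source may have more. Where it says the series, first, only, none or still open, it means among the compounds named here.

Of the compounds shown here, two on a shared core have numbers so far in an ADME assay for permeability, using PAMPA, in phosphate buffer, with a stated time of 18 h (on this read-out lower numbers stand for lower permeability and higher numbers for higher permeability), for this series. Compound 1 (`COc1cc2nc(-c3ccc(C)o3)cc(NCC3CCN(Cc4ccc(C(=O)NO)cc4)CC3)c2cc1OC`) reads 5.56 nm/s there, and compound 2 (`COc1cc2nc(-c3ccc(C)o3)cc(NCC3CCN(Cc4ccc(C(=O)NO)s4)CC3)c2cc1OC`) reads 4.01 nm/s there, so compound 2 stands level with compound 1 once the usual scatter is allowed for. Compound 3 (`COc1cc2nc(-c3ccc(C)o3)cc(NCC3CCN(C4CC(C(=O)NO)C4)CC3)c2cc1OC`) keeps the shared core and differs from compound 2 in one place (a group of 8 heavy atoms (5 carbon, 1 nitrogen, 2 oxygen; one four-membered non-aromatic ring of carbon only) in place of a group of 10 heavy atoms (6 carbon, 1 nitrogen, 2 oxygen, 1 sulfur; one five-membered aromatic ring with 1 hetero atom), on an amine nitrogen in a ring) on an amine nitrogen in a ring. A five-membered aromatic ring gives way to a four-membered non-aromatic ring of carbon only.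

Among the compounds with values here, only one measured step bears on this (a 1.4-fold lower number from compound 1 to compound 2 (0.14 log units; within the scatter)) and it lies within the scatter. That step exchanged one aromatic ring for another, so it is a weak guide to a change that removes the aromatic ring altogether. Within the data shown here, no compound measured so far carries a non-aromatic ring at this place. With nothing pointing either way, no move beyond the scatter is expected in this assay for this change. The step expected is small (a 1.1-fold lower number from compound 2 to compound 3 (0.06 log units; within the scatter)) and the uncertainty around it is wide. For compound 3 the estimated value is 3.5 nm/s with an expected range of 1.2 nm/s to 9 nm/s around it.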

Compound 3, apparent permeability: 0.68 nm/s
Beside the measured number, compound 3's estimate is 5.1-fold (0.71 log units) above it; the whole stated range lies above it.
By their numbers in this assay, from the lowest: compound 3; then compounds 2 and 1 (each within the scatter of the next).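

In this assay, the group on the amine nitrogen in a ring turns out to matter: exchanging one aromatic ring for another left the number within the scatter, but the four-membered non-aromatic ring of carbon only brings a 5.9-fold lower number from compound 2 to compound 3 (0.77 log units; beyond the scatter), and set against the phenyl-bearing compound the fall is an 8.2-fold lower number from compound 1 to compound 3 (0.91 log units; beyond the scatter). So tolerance of this place holds across the two aromatic groups and does not extend to this non-aromatic one, which makes compound 3 the lowest of the three, with both of its steps beyond the scatter. No accompanying measurement accounts for this fall.

The change also alters several things at once, since the entering group loses the aromatic ring, has a different ring size and holds fewer heavy atoms, and these three compounds cannot tell which of these goes with the lower number. A cyclohexane ring carrying the same hydroxycarbamoyl group at this place would keep the larger ring size without aromaticity, and so would begin to pull these apart.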